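Replacing Butyl with Ethoxy: an Expected Dose in Mice

The source may hold more compounds than are shown below. What is called first, only, known or untested is meant among the compounds shown, and "the series" means these compounds.

Compound 1 `CCCCc1nc(N)c2nc(O)n(Cc3ccccc3)c2n1`: 0.3 mg/kg
Compound 2 `Nc1ncnc2c1nc(O)n2Cc1ccc(Cl)cc1`: 30 mg/kg
Compound 3 `CCCCCNc1nc(N)c2nc(O)n(Cc3ccccc3)c2n1`: 0.3 mg/kg

In a functional assay on the whole organism for activation, with Mus musculus as the target (a lower number here means that less compound is needed, a higher number that more compound is needed for the effect), compound 1 is level with compound 3, and together they give the lowest of the three numbers; compound 2 sits far higher. Among the measured compounds shown here, the one single-point step, no change at the digits printed from compound 1 to compound 3 (within the scatter), shows that pentylamino in place of butyl on an aromatic carbon leaves the number unchanged. Compound 4 `CCOc1nc(N)c2nc(O)n(Cc3ccccc3)c2n1` differs from compound 1 by ethoxy in place of butyl on an aromatic carbon. For the measured compounds named here, no measured step swaps butyl for ethoxy, so compound 3 is the closest guide, and its unchanged value suggests this position tolerates change; compound 2, which carries no such group, gives a much higher number. The step of a 3.3-fold higher number from compound 1 to compound 4 (0.52 log units; beyond the scatter) is expected to be small. Compound 4 is therefore expected at 1 mg/kg, between 0.3 mg/kg and 3 mg/kg.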

Compound 4, minimum effective dose: 0.3 mg/kg
The estimate for compound 4 lay 3.3-fold (0.52 log units) above the measured number; low and high end bracket the measured number.
By their numbers in this assay, from the lowest: compounds 1, 3 and 4 (each within the scatter of the next); then compound 2.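

In this assay the steps of no change at the digits printed from compound 1 to compound 4 (within the scatter) and no change at the digits printed from compound 3 to compound 4 (within the scatter) show that ethoxy does as well here as butyl and pentylamino. This position, between two ring nitrogen atoms, thus takes a group of only 3 heavy atoms, with an oxygen and a hydrogen-bond acceptor that butyl lacks, and the dose stays level. No measurement available here explains this tolerance.

A carboxylic acid or a much longer chain at this position could still change the dose. On these data alone, how far the tolerance extends therefore remains open.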